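The source may hold more compounds than are shown below. What is called first, only, known or untested is meant among the compounds shown, and "the series" means these compounds.

Compound 1, `Cc1cc(-c2ccco2)c(S(C)(=O)=O)cc1C(=O)N=C(N)N`: 16 nM
Compound 2, `Cc1cc(OCc2ccccc2)c(S(C)(=O)=O)cc1C(=O)N=C(N)N`: 28 nM

In a functional assay for inhibition of sodium/hydrogen exchanger (Oryctolagus cuniculus) (on this read-out lower numbers stand for stronger inhibition and higher numbers for weaker inhibition), compound 2 stands with the higher of the two numbers, while compound 1 gives 16 nM; the step of a 1.8-fold higher number from compound 1 to compound 2 (0.24 log units; within the scatter) is within the scatter, so the two compounds cannot be ordered.

Compound 3, `COc1cc(C)c(C(=O)N=C(N)N)cc1S(C)(=O)=O`, has not yet been measured. It differs from compound 2 by hydrogen in place of phenyl on a saturated chain carbon bound to an oxygen on an aromatic ring. Going by the values given here, no measured pair shows this exact change. Among the compounds with values here, the only measured step, a 1.8-fold higher number from compound 1 to compound 2 (0.24 log units; within the scatter), exchanged one group for another at the same aromatic carbon without a difference beyond the scatter, and that is all the measured compounds say about this position. Removing the phenyl leaves a much smaller group there, and the data give no guide to how much that matters, so compound 3 is expected to lie near compound 2 or somewhat weaker, with a 1.6-fold higher number from compound 2 to compound 3 (0.21 log units; within the scatter) as the estimated step. The estimate for compound 3 in this assay is 45 nM, in the range 15 nM to 140 nM.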

Compound 3, half-maximal inhibitory concentration: 16 nM
For compound 3 the middle estimate is 2.8-fold (0.45 log units) above the measured one; the measured number falls inside the stated range.
By their numbers in this assay, from the lowest: compounds 1, 3 and 2 (each within the scatter of the next).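

In this assay the step to methoxy gives a 1.8-fold lower number from compound 2 to compound 3 (0.24 log units; within the scatter) and the exchange of furan-2-yl gives no change at the digits printed from compound 1 to compound 3 (within the scatter), so neither step can be told from the scatter. Going by these compounds alone, the phenyl on the saturated chain carbon is therefore not needed to keep the number in this range, and the one earlier step could not show this: at this aromatic carbon, furan-2-yl, benzyloxy and methoxy cannot be told apart in compound 1, compound 2 and compound 3. No supporting evidence bears on why these three groups read alike.

On these data alone, it remains open whether this tolerance extends to an amine, a carboxylic acid or a longer chain on the same aromatic carbon. As far as these compounds go, it is equally open whether plain hydrogen there, with no oxygen-linked group at all, would keep the number in the same range.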